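Extending a fluoroalkoxy chain on a shared core

The compounds below may be only part of what the source reports. "The series", "measured", "known", "first", "only" and "open" are said of these compounds alone.

Of the compounds shown here, three built on a shared core have been measured in an assay on brain for displacement of a labelled ligand from Sigma non-opioid intracellular receptor 1 (Rattus norvegicus); a higher number here means a weaker inhibitor, a lower number a stronger inhibitor. Compound 1 `COc1cc2c(cc1OC)CN(CCCCc1cn(-c3ccc(F)cc3)c3ccccc13)CC2` gives 531 nM, compound 2 `FCCOc1ccc(N2CCN(CCCCc3cn(-c4ccc(F)cc4)c4ccccc34)CC2)cc1` gives 614 nM, and compound 3 `FCCOCCOc1ccc(N2CCN(CCCCc3cn(-c4ccc(F)cc4)c4ccccc34)CC2)cc1` gives 1110 nM. Compound 3 therefore sits within the scatter of compound 2, while its gap to compound 1 lies beyond the scatter, compound 3 giving the higher number. For the measured compounds named here, only one step between measured compounds that differ in a single place has been taken, namely a 1.8-fold higher number from compound 2 to compound 3 (0.26 log units; within the scatter), a chain extension that changed the number by no more than the scatter. Compound 4 `FCCOCCOCCOc1ccc(N2CCN(CCCCc3cn(-c4ccc(F)cc4)c4ccccc34)CC2)cc1` repeats that kind of extension one unit further out: 2-fluoroethoxy in place of fluoro on a saturated chain carbon, two bonds along the chain from an oxygen on a saturated carbon. Going by the values given here, because the only comparable step was a 1.8-fold higher number from compound 2 to compound 3 (0.26 log units; within the scatter), the step of a 1.4-fold higher number from compound 3 to compound 4 (0.16 log units; within the scatter) is expected to be of similar size, leaning toward a higher number but not clearly beyond the scatter. Compound 4 is thus estimated at 1600 nM in this assay, with a range from 700 nM to 3800 nM.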

Compound 4, inhibition constant: 2160 nM
Estimate against measurement, compound 4: 1.4-fold (0.13 log units) below, within the range that was stated.
By their numbers in this assay, from the lowest: compounds 1, 2, 3 and 4 (each within the scatter of the next, the first and the last beyond it).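

In this assay, the further extension gives a 1.9-fold higher number from compound 3 to compound 4 (0.29 log units; within the scatter), so this single added unit, like the one before it, cannot be told apart from ordinary assay variation. Taken together, however, the two extensions give a 3.5-fold higher number from compound 2 to compound 4 (0.55 log units; beyond the scatter), which makes 2-(2-fluoroethoxy)ethoxy the first chain in this short series that is clearly separated from the 2-fluoroethyl end of compound 2, and no compound among these three runs against that direction. Nothing available explains why the number rises with this extension.

Still open, from the compounds shown here alone, is whether a longer chain of the same repeating kind would continue the rise or level off. Also open, going by these compounds, is whether the end fluoro itself matters, which a hydroxyl or a methoxy in its place on the same chain would test.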